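Methyl on the Amine Nitrogen of Compound 2

A few compounds are considered here, and "the series" means these few. Any claim that something is new, unique, unknown or untested is made for them only; others in the source may bear on it.

In an ADME assay on L02 cells (Homo sapiens) for cytotoxicity, read by MTT assay, with a stated time of 72 h (a lower number here means a stronger inhibitor, a higher number a weaker inhibitor), compound 1 (`COc1ccc(/C=C2\CNC/C(=C\c3ccc(OC)c(OC)c3)C2=O)cc1OC`) gives 15100 nM and compound 2 (`COc1cc(/C=C2\CNC/C(=C\c3cc(OC)c(OC)c(OC)c3)C2=O)cc(OC)c1OC`) gives 7600 nM, so these two values lie within the usual scatter of each other. Compound 3 (`COc1cc(/C=C2\CN(C)C/C(=C\c3cc(OC)c(OC)c(OC)c3)C2=O)cc(OC)c1OC`) is compound 2 with one change: methyl in place of hydrogen on an amine nitrogen in a ring. For the measured compounds named here, no measured pair shows this change, so no step beyond the scatter is expected in this assay, and no firm direction. The expected result is a 1.1-fold lower number from compound 2 to compound 3 (0.04 log units; within the scatter). Compound 3 is estimated at 7000 nM, with an expected range of 2500 nM to 20000 nM.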

Compound 3, half-maximal inhibitory concentration: 26400 nM
Compound 3: the middle estimate sits 3.8-fold (0.58 log units) below what was measured, outside the stated range (above it).
By their numbers in this assay, from the lowest: compounds 2, 1 and 3 (each within the scatter of the next, the first and the last beyond it).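

Methyl in place of hydrogen on an amine nitrogen in a ring gives a 3.5-fold higher number from compound 2 to compound 3 (0.54 log units; beyond the scatter) in this assay and is the first single-place change seen here. It shows that this nitrogen is not a silent position, as one added carbon moves the number beyond the scatter. Nothing measured here explains the step.

On these data alone, whether a longer chain such as ethyl, or an acetyl group, on this nitrogen would raise the number further stays open. So does whether the same methyl change on compound 1 would give a similar step.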